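This account rests on a few compounds, and the source may have more. Where it says the series, first, only, none or still open, it means among the compounds named here.

Series notes, step from compound 2 to compound 3.

Two compounds of the shared core have numbers in a functional assay on the whole organism for inhibition, with Mythimna separata as the target, with a stated time of 5 days (on this read-out higher numbers stand for an effect only at larger amounts of compound and lower numbers for an effect already at smaller amounts), so far. Compound 1 `CC(C)(C)n1ncc(OCc2nnc(-c3ccc(Br)cc3)o2)c(Cl)c1=O` gives 21.4 ug/mL in this assay. Compound 2 `CC(C)(C)n1ncc(OCc2nnc(-c3ccc(Cl)cc3)o2)c(Cl)c1=O` gives 1.9 ug/mL in this assay. Going by the values given here, the one measured step, an 11-fold lower number from compound 1 to compound 2 (1.05 log units; beyond the scatter), is the whole of the record on this series. On these two numbers compound 2 stands lowest, and its nearest neighbour is compound 1.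

Compound 3 `CC(C)(C)n1ncc(OCc2nnc(-c3ccc(Cl)cc3F)o2)c(Cl)c1=O` differs from compound 2 by fluoro in place of hydrogen on an aromatic carbon. Among the compounds with values here, no measured step bears on this change: the step from compound 1 to compound 2 exchanges one halogen for another at the carbon that already carries a halogen, whereas the new fluoro enters at a carbon that was bare in both measured compounds, and its size therefore gives no direction for the present change. Beyond the scatter nothing is expected in either direction, and an estimate is taken close to the number of compound 2, with a wide range to cover the lack of a comparable step; compound 3 is estimated at 2.5 ug/mL in this assay, between 0.8 ug/mL and 8 ug/mL, meaning an expected step of a 1.3-fold higher number from compound 2 to compound 3 (0.12 log units; within the scatter).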

Compound 3, half-maximal effective concentration: 10.4 ug/mL
Compound 3: middle estimate off by 4.2-fold (0.62 log units), on the low side, outside the stated range (above it).
By their numbers in this assay, from the lowest: compound 2; then compound 3; then compound 1.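

In this assay, going by these compounds alone, the aromatic carbon ortho to a large group, bare in the earlier compounds, proves sensitive to substitution: the change from 4-chlorophenyl to 4-chloro-2-fluorophenyl gives a 5.5-fold higher number from compound 2 to compound 3 (0.74 log units; beyond the scatter), so even a single added fluoro moves the number beyond the scatter and in the unfavourable direction. The gain of the 4-chlorophenyl over the 4-bromophenyl is not wholly lost, since 4-chloro-2-fluorophenyl in place of 4-bromophenyl still gives a 2.1-fold lower number from compound 1 to compound 3 (0.31 log units; beyond the scatter), a smaller step than an 11-fold lower number from compound 1 to compound 2 (1.05 log units; beyond the scatter), and the series now shows that the aryl group tolerates little change on either of the two carbons examined. No measured property of these compounds is available to account for the rise from the added fluoro.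

On these data alone, whether this rise belongs to fluoro itself or to any group at this carbon remains open, and a methyl, a methoxy or an amine at the same place would separate the two. Also open, as far as these compounds go, is whether fluoro on the same carbon of the 4-bromophenyl would move the number in the same direction and by a similar amount.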